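The source may hold more compounds than are shown below. What is called first, only, known or untested is meant among the compounds shown, and "the series" means these compounds.

In an assay on isolated protein for inhibition of Rho-associated protein kinase 1 (Homo sapiens), read by scintillation counting, radiometric assay and 33P incorporation, with a stated time of 40 min, in the presence of a further agent that is not named here (a lower number here means a stronger inhibitor, a higher number a weaker inhibitor), compound 2 `CCCC(=O)Nc1cccc(NC(=O)COc2ccc3c(=O)ccoc3c2)c1` gives 1430 nM, and this is the only number shown for the two measured compounds. Compound 1 `COc1cccc(OCC(=O)Nc2cccc(NC(=O)c3ccc(N(C)C)cc3)c2)c1` is the other measured compound. In this assay compound 1 gives > 10000 nM, which is a limit of the assay and not a number. Going by the values given here, compound 2 therefore stands alone as a measured value, the one other value being (the limit of > 10000 nM in this assay, at which 1 of the 2 values shown sits). Compound 3 `O=C(COc1ccc2c(=O)ccoc2c1)Nc1cccc(NC(=O)c2ccc([N+](=O)[O-])cc2)c1` differs from compound 2 by 4-nitrophenyl in place of propyl on a carbonyl carbon. Among the compounds with values here, no measured step covers such a change, so a shift within the usual scatter is expected, in either direction. Compound 3 is estimated at 1000 nM, expected between 300 nM and 4000 nM. The expected step is a 1.4-fold lower number from compound 2 to compound 3 (0.16 log units; within the scatter).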

Compound 3, half-maximal inhibitory concentration: 67 nM
The estimate for compound 3 lay 15-fold (1.17 log units) above the measured number; measured number below the stated range.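

In this assay, going by these compounds alone, the carbonyl carbon whose other neighbour is the amide-type nitrogen proves sensitive to the group it carries: 4-nitrophenyl in place of propyl gives a 21-fold lower number from compound 2 to compound 3 (1.33 log units; beyond the scatter), the first measured step at this place. The earlier compounds shown here alone offered no comparison there. Nothing shown gives a cause for this step.

The compounds shown do not separate the effect of the ring from that of its nitro group. A plain phenyl or a 4-aminophenyl at this place would tell the two apart.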